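This account rests on a few compounds, and the source may have more. Where it says the series, first, only, none or still open, it means among the compounds named here.

Working notes on the series. Binding in an assay for binding affinity to dual specificity mitogen-activated protein kinase kinase 4 (Homo sapiens), read by KINOMEscan, tested at 100 nM (a lower number here means a stronger effect, a higher number a weaker effect of the compound at the concentration tested), is followed for a set of three compounds that share one core and differ only in the aryl group attached to it. Compound 1 `CCCS(=O)(=O)Nc1ccc(F)c(C(=O)c2n[nH]c3ncc(-c4ccccc4Cl)cc23)c1F` gives 9.3% in this assay. For the measured compounds named here, compound 2 `CCCS(=O)(=O)Nc1ccc(F)c(C(=O)c2n[nH]c3ncc(-c4ccc(C(C)(C)C)cc4)cc23)c1F` gives 46% in this assay, the highest of the two numbers so far; its nearest neighbour is compound 1, and the single step that connects them, 4-(tert-butyl)phenyl in place of 2-chlorophenyl on an aromatic carbon, is a number 36.7 percentage points higher from compound 1 to compound 2 (beyond the scatter). Compound 3 `CCCS(=O)(=O)Nc1ccc(F)c(C(=O)c2n[nH]c3ncc(-c4ccc(Cl)c(C(F)(F)F)c4)cc23)c1F` is the next compound to be measured. It differs from compound 2 by 4-chloro-3-(trifluoromethyl)phenyl in place of 4-(tert-butyl)phenyl on an aromatic carbon. Going by the values given here, the only measured step bears on this change indirectly, since it shows that an exchange of the aryl group can move the number by a large amount. For compound 3 a step of a number 18 percentage points lower from compound 2 to compound 3 (beyond the scatter) is expected, in the direction of compound 1 but without reaching it. Compound 3 is estimated at 28%, within 6% to 65%.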

Compound 3, a percentage reported as activity, at one concentration (the size of the read-out at that concentration, not a potency): 15%
For compound 3 the middle estimate is 13 percentage points above the measured one; measured number inside the range.
By their numbers in this assay, from the lowest: compounds 1 and 3 (each within the scatter of the next); then compound 2.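

In this assay the exchange of 4-(tert-butyl)phenyl for 4-chloro-3-(trifluoromethyl)phenyl gives a number 31 percentage points lower from compound 2 to compound 3 (beyond the scatter) and so shows that a low number at this position is not confined to the 2-chlorophenyl group of compound 1. The comparison of the two chlorinated aryl groups gives a number 5.7 percentage points higher from compound 1 to compound 3 (within the scatter) and sets no order between them, so that among these three compounds only the 4-(tert-butyl)phenyl group of compound 2 stands apart. Nothing at hand accounts for this difference.

Going by these compounds, what 4-chlorophenyl alone or 3-(trifluoromethyl)phenyl alone would give on the shared core remains open. Also open, on these data alone, is whether this position tolerates a group other than a substituted phenyl, such as a morpholine or a carboxylic acid.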